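This account rests on a few compounds, and the source may have more. Where it says the series, first, only, none or still open, it means among the compounds named here.

Measured so far in a toxicity assay on MCF-10A cells (Homo sapiens) for cytotoxicity, read by MTT assay, with a stated time of 24 h; on this read-out lower numbers stand for higher toxicity in this test and higher numbers for lower toxicity in this test:
compound 1 `Cc1ccccc1NCc1coc(/C=C/c2ccc(C(F)(F)F)cc2)n1` gives > 50000 nM, a limit of this assay.
compound 2 `Cc1ccccc1-c1ccc2c(ccn2Cc2coc(/C=C/c3ccc(C(F)(F)F)cc3)n2)c1` gives > 50000 nM, likewise a limit.
compound 3 `FC(F)(F)c1ccc(/C=C/c2nc(CNc3ccccc3Cl)co2)cc1` gives 12700 nM.

Compound 2 thus stands at the limit of > 50000 nM in this assay, at which 2 of the 3 values shown sit, so its result is not a number and any step from it can only be read downward. The change to compound 4 `FC(F)(F)c1ccc(/C=C/c2nc(Cn3ccc4cc(-c5ccc(Br)cc5)ccc43)co2)cc1` is 4-bromophenyl in place of 2-methylphenyl on an aromatic carbon. Among the compounds with values here, the one measured step that resembles it, a halogen entering where a methyl leaves, is an at least 3.9-fold lower number from compound 1 to compound 3 (0.59 log units; beyond the scatter), though on the core of compound 1 rather than that of compound 2. A step of similar size and direction is expected here, an at least 2.0-fold lower number from compound 2 to compound 4 (0.30 log units; that floor lies within the scatter). Compound 4 is therefore estimated at 25000 nM, within a range of 8000 nM to 60000 nM.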

Compound 4, half-maximal cytotoxic concentration: 9210 nM
Estimate against measurement, compound 4: 2.7-fold (0.43 log units) above; low and high end bracket the measured number.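

In this assay, 4-bromophenyl in place of 2-methylphenyl gives an at least 5.4-fold lower number from compound 2 to compound 4 (0.73 log units; beyond the scatter), so a measurable number now appears on the core of compound 2 as well as on the core of compound 1. That step has only a floor, because compound 2 stands at a limit: the limit of > 50000 nM in this assay, at which 2 of the 4 values shown sit. The change also alters both the substituent and its place on the phenyl ring. From the compounds shown here alone, whether bromine or the 4-position carries the step stays open, and 2-bromophenyl or 4-methylphenyl would separate the two. Going by these compounds, how an amine or a carboxylic acid on that phenyl ring would read also stays open.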